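Swapping a saturated ring for a chloropyridine ether

The source may hold more compounds than are shown below. What is called first, only, known or untested is meant among the compounds shown, and "the series" means these compounds.

Measured so far:
compound 1 `Cc1cc(SC(C)(C)C)c(S(C)(=O)=O)cc1C(=O)N=C(N)N` — 22 nM
compound 2 `Cc1cc(Sc2ccccc2Cl)c(S(C)(=O)=O)cc1C(=O)N=C(N)N` — 14 nM
compound 3 `Cc1cc(OC2CCCCC2)c(S(C)(=O)=O)cc1C(=O)N=C(N)N` — 37 nM

All three were tested in a functional assay for inhibition of sodium/hydrogen exchanger (Oryctolagus cuniculus); a lower number here means a stronger inhibitor, a higher number a weaker inhibitor. Compound 3 shows the highest number of the three. The gap a 1.7-fold higher number from compound 1 to compound 3 (0.23 log units; within the scatter) is within the scatter, so compound 3 and compound 1 cannot be told apart, while a 2.6-fold higher number from compound 2 to compound 3 (0.42 log units; beyond the scatter) is beyond the scatter, making compound 3 a modestly weaker inhibitor than compound 2.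

Compound 4 `Cc1cc(Oc2cncc(Cl)c2)c(S(C)(=O)=O)cc1C(=O)N=C(N)N` has not yet been measured. It differs from compound 3 in one place: 5-chloropyridin-3-yl in place of cyclohexyl on an oxygen on an aromatic ring. The nearest measured precedent is the change from tert-butyl to 2-chlorophenyl on a sulfur, where a 1.6-fold lower number from compound 1 to compound 2 (0.20 log units; within the scatter). That step swapped a non-aromatic carbon group for a chlorinated aromatic ring, on a sulfur rather than on an oxygen, and barely moved the number. Among the measured compounds shown here, the present change also brings in a ring nitrogen, for which no measured pair exists, so the precedent is imperfect. Taking it at face value, the expected step is a 1.5-fold lower number from compound 3 to compound 4 (0.17 log units; within the scatter), within the scatter. Compound 4 is therefore estimated at 25 nM, with a range from 10 nM to 70 nM.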

Compound 4, half-maximal inhibitory concentration: 14 nM
The estimate for compound 4 lay 1.8-fold (0.25 log units) above the measured number, within the range that was stated.
By their numbers in this assay, from the lowest: compounds 2, 4, 1 and 3 (each within the scatter of the next, the first and the last beyond it).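

Among the compounds shown here, with the oxygen held constant, the group on it can now be judged by itself: in this assay, 5-chloropyridin-3-yl in place of cyclohexyl gives a 2.6-fold lower number from compound 3 to compound 4 (0.42 log units; beyond the scatter), whereas the earlier compounds offered only one group on an oxygen and so no such comparison. Exchanging the whole group on the aromatic carbon gives no change at the digits printed from compound 2 to compound 4 (within the scatter) and a 1.6-fold lower number from compound 1 to compound 4 (0.20 log units; within the scatter), so compound 4 cannot be told apart from either sulfur-linked compound, and a (5-chloropyridin-3-yl)oxy group serves here as well as (2-chlorophenyl)sulfanyl or (tert-butyl)sulfanyl. Nothing available explains why the number falls on leaving cyclohexyl.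

The step from compound 3 to compound 4 brings in an aromatic ring, a ring nitrogen and a chlorine all at once, and the compounds shown do not separate these three changes. A plain phenyl or a 2-chlorophenyl on the same oxygen would begin to pull them apart, and the second would also set oxygen directly against sulfur with the same group attached.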